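The source may report more compounds than this note shows. Statements on the series, on what has been measured and on what is new or still open speak of the compounds shown alone.

Measured so far:
- compound 1 `CC(C)(C)[C@H]1CC[C@H](N(Cc2ccc(C(=O)NCCC(=O)O)cc2)C(=O)Nc2ccc(C#N)cc2)CC1` — 1050 nM
- compound 2 `CCN(CC)C(=O)c1ccc(NC(=O)N(Cc2ccc(C(=O)NCCC(=O)O)cc2)[C@H]2CC[C@H](C(C)(C)C)CC2)cc1` — 2430 nM

Among the measured compounds shown here, in an in vitro assay on BHK cells for inhibition of Glucagon receptor (Homo sapiens) (on this read-out higher numbers stand for weaker inhibition and lower numbers for stronger inhibition), compound 1 gives 1050 nM, the lowest of the two numbers; the only neighbour is compound 2, with a 2.3-fold higher number from compound 1 to compound 2 (0.36 log units; beyond the scatter) as the single measured step. Compound 3 `CC(C)(C)[C@H]1CC[C@H](N(Cc2ccc(C(=O)NCCC(=O)O)cc2)C(=O)Nc2ccc(C#N)cc2OC(F)(F)F)CC1` differs from compound 1 by trifluoromethoxy in place of hydrogen on an aromatic carbon, placed ortho to a large group and meta to a cyano group. For the measured compounds named here, no measured step touches this position, so the one known step offers no direct guide. A change of about the scatter, in either direction, is expected, so a 1.3-fold lower number from compound 1 to compound 3 (0.12 log units; within the scatter) is the working expectation. For compound 3 the estimate is 800 nM, with a range from 300 nM to 2500 nM.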

Compound 3, half-maximal inhibitory concentration: 215 nM
The estimate for compound 3 lay 3.7-fold (0.57 log units) above the measured number; measured number outside the range, below it.
By their numbers in this assay, from the lowest: compound 3; then compound 1; then compound 2.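

In this assay, a substituent is accepted on the aromatic carbon ortho to a large group and meta to a cyano group: trifluoromethoxy in place of hydrogen gives a 4.9-fold lower number from compound 1 to compound 3 (0.69 log units; beyond the scatter). Among the compounds shown here, the earlier step changed the cyano group itself and moved the number the other way, a 2.3-fold higher number from compound 1 to compound 2 (0.36 log units; beyond the scatter), so this is the first lowering seen, resting on a single example. Nothing at hand accounts for the size of this step.

From the compounds shown here alone, whether a methoxy group, a trifluoromethyl group or a chlorine atom on this carbon would give a similar step remains open. Also open, going by these compounds, is whether the step carries over to the diethylcarbamoyl compound 2.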